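Urea to Amide on a Shared Core

The source may hold more compounds than are shown below. What is called first, only, known or untested is meant among the compounds shown, and "the series" means these compounds.

For the measured compounds named here, compound 1 `COc1cc(-c2nn(-c3cccc(NC(=O)Nc4ccc(Cl)c(Cl)c4)c3)cc2-c2ccncc2)ccc1Cl` was tested in a functional assay on KM12 cells (Homo sapiens) for inhibition, read by sulforhodamine B assay, with a stated time of 48 h (on this read-out lower numbers stand for stronger inhibition of growth and higher numbers for weaker inhibition of growth), where compound 1 gives 2770 nM, the lowest of the two numbers known here. In this assay compound 2 `O=C(Nc1cccc(-n2cc(-c3ccncc3)c(-c3ccc(Cl)c(O)c3)n2)c1)Nc1ccc(Cl)c(Cl)c1` gives 4470 nM. The step of a 1.6-fold higher number from compound 1 to compound 2 (0.21 log units; within the scatter) comes from hydrogen in place of methyl on an oxygen on an aromatic ring. Compound 3 `COc1cc(-c2nn(-c3cccc(NC(=O)c4ccc(Cl)c(C(F)(F)F)c4)c3)cc2-c2ccncc2)ccc1Cl` differs from compound 1 elsewhere: 4-chloro-3-(trifluoromethyl)phenyl in place of (3,4-dichlorophenyl)amino on a carbonyl carbon. Going by the values given here, no measured step touches this carbonyl carbon, so the single known step gives no guide, and no direction can be drawn from it. The estimate for compound 3 is 3000 nM, between 800 nM and 12000 nM. This means an expected step of a 1.1-fold higher number from compound 1 to compound 3 (0.03 log units; within the scatter), with wide uncertainty.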

Compound 3, concentration for total growth inhibition: > 32500 nM
Compound 3: no number, only a limit (the forecaster's own chance of this, stated with the estimate: 10%); at least 10-fold (1.03 log units) between middle value and limit.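

The carbonyl carbon is a place where a change counts in this assay: replacing (3,4-dichlorophenyl)amino with 4-chloro-3-(trifluoromethyl)phenyl gives an at least 11-fold higher number from compound 1 to compound 3 (1.06 log units; beyond the scatter), so growth inhibition is much weaker, whereas the earlier step on the oxygen stayed within the scatter. For compound 3, the reading is only a limit: the limit of > 32500 nM in this assay, at which 1 of the 3 values shown sits.

From the compounds shown here alone, the swap removes the amino nitrogen and changes the ring substituents at once, so which of these matters remains open. A 3,4-dichlorophenyl group on this carbonyl carbon, or a (4-chloro-3-(trifluoromethyl)phenyl)amino group, would separate the two.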